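Halogens on the aniline ring of an inactive series

The source may hold more compounds than are shown below. What is called first, only, known or untested is meant among the compounds shown, and "the series" means these compounds.

Compound 1 (`C=C[C@@](C)(/C=C/c1ccc(Nc2ccc(OC)cc2)cc1)CCC=C(C)C`) is the starting point here. In a functional assay on Raji cells (Homo sapiens) for cytotoxicity, with a stated time of 72 h (a lower number here means that less compound is needed, a higher number that more compound is needed for the effect), compound 1 gives > 26000 nM as a limit of the assay and not a number. Compound 2 (`C=C[C@@](C)(/C=C/c1ccc(Nc2ccc(OC)c(OC)c2)cc1)CCC=C(C)C`) also reaches only a limit at > 26000 nM in the same test. Compound 3 (`C=C[C@@](C)(/C=C/c1ccc(Nc2ccc(OC(F)(F)F)cc2)cc1)CCC=C(C)C`) likewise gives > 26000 nM as a limit. Compound 1 therefore has no number to stand on, and the record is simply the limit of > 26000 nM in this assay, at which 3 of the 3 values shown sit, and nothing more.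

Compound 4 (`C=C[C@@](C)(/C=C/c1ccc(Nc2ccc(Cl)c(F)c2)cc1)CCC=C(C)C`) carries 4-chloro-3-fluorophenyl in place of 4-methoxyphenyl on a nitrogen on an aromatic ring. Two measured changes on that same ring bear on it. Methoxy in place of hydrogen on an aromatic carbon is a step that the two limits leave unreadable from compound 1 to compound 2 and trifluoromethyl in place of methyl on an oxygen is a step that the two limits leave unreadable from compound 1 to compound 3 in size. Neither gives a size or a direction to carry over, so no step beyond the scatter is expected in this assay for this change. The estimated move is a number no higher from compound 1 to compound 4 (the limit leaves the size open) with no firm direction expected. Compound 4 is expected near 26000 nM with an estimated range of 10000 nM to 45000 nM and may well report only a limit.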

Compound 4, half-maximal effective concentration: > 26000 nM
Compound 4: a limit, no number; the forecaster's own chance of this, stated with the estimate: 75%; the middle value lies on the limit itself.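

Compound 4 also reports only a limit, so no step from compound 1 to compound 4 can be read, and neither compound offers a number to compare: the limit of > 26000 nM in this assay, at which 4 of the 4 values shown sit.

The compounds shown leave open whether any change on this aniline ring, or elsewhere on the shared core, would give a measurable value in this assay.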